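Taking the bromo group off compound 3

The source may report more compounds than this note shows. Statements on the series, on what has been measured and on what is new or still open speak of the compounds shown alone.

In a functional assay on HeLa cells (Homo sapiens) for inhibition, read by MTT assay (a lower number here means a stronger inhibitor, a higher number a weaker inhibitor), compound 1 (`CC1(C)C2CCC1(C)C(OC(=O)/C=C/c1ccc(O)c(O)c1[N+](=O)[O-])C2`) stands at 13900 nM while compound 2 (`O=C(/C=C/c1ccc(O)c(O)c1[N+](=O)[O-])OCCc1ccccc1`) stands at 10900 nM on the same scale. Compound 3 (`CC1(C)C2CCC1(C)C(OC(=O)/C=C/c1cc(O)c(O)c(Br)c1)C2`) reaches 22700 nM and so holds the highest of the three numbers, within the scatter of compound 1 but beyond it from compound 2. Compound 4 (`CC1(C)C2CCC1(C)C(OC(=O)/C=C/c1ccc(O)c(O)c1)C2`) has hydrogen in place of bromo on an aromatic carbon. Within the data shown here, no measured pair shows this change alone. In this assay no step beyond the scatter is expected, and any move should be slightly downward. An expected 1.1-fold lower number from compound 3 to compound 4 (0.05 log units; within the scatter) would stay within the scatter. Compound 4 is expected at 20000 nM (estimated range 9000 nM to 45000 nM).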

Compound 4, half-maximal inhibitory concentration: 20600 nM
Compound 4: the middle estimate sits 1.0-fold (0.01 log units) below what was measured; the measured number falls inside the stated range.
By their numbers in this assay, from the lowest: compounds 2, 1, 4 and 3 (each within the scatter of the next, the first and the last beyond it).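

In this assay, hydrogen in place of bromo gives a 1.1-fold lower number from compound 3 to compound 4 (0.04 log units; within the scatter), and hydrogen in place of nitro gives a 1.5-fold higher number from compound 1 to compound 4 (0.17 log units; within the scatter). On this ester, then, neither the bromo group nor the nitro group separates from plain hydrogen on the aromatic ring, so neither is needed for the level of inhibition seen here. No supporting data bear on this result. From the compounds shown here alone, whether an amine or a carboxylic acid on this aromatic carbon would produce a step beyond the scatter remains open. So does whether hydrogen in place of nitro would behave alike with the ester group of compound 2.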